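A few compounds are considered here, and "the series" means these few. Any claim that something is new, unique, unknown or untested is made for them only; others in the source may bear on it.

Of the compounds shown here, three of a shared core have been measured in a functional assay for agonist activity at Free fatty acid receptor 1 (Homo sapiens), read by FLIPR, in the presence of a further agent that is not named here; on this read-out higher numbers stand for an effect only at larger amounts of compound and lower numbers for an effect already at smaller amounts. Compound 1 `Cc1ccnc(Oc2ccc(CC3SC(=O)NC3=O)cc2)c1` stands at the highest number of the three, giving 4280 nM. Compound 2 `COc1cc(Oc2ccc(Cl)cc2Cl)ccc1CC1SC(=O)NC1=O` gives 1410 nM, and compound 3 `Cc1cc(Oc2ccc(CC3SC(=O)NC3=O)cc2)nc(C(F)(F)F)c1` gives 688 nM. For the measured compounds named here, the one step that changes a single place, a 6.2-fold lower number from compound 1 to compound 3 (0.79 log units; beyond the scatter), comes from a trifluoromethyl in place of hydrogen on an aromatic carbon.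

Compound 4 `O=C1NC(=O)C(Cc2ccc(Oc3ccccc3)cc2)S1` has not been measured. Compared with compound 1 it shows (phenyl in place of 4-methylpyridin-2-yl on an oxygen on an aromatic ring). Going by the values given here, no measured pair bears directly on this change: the only single-place step adds a group, whereas here one ring is exchanged for another and a methyl and a ring nitrogen are lost. Compound 2 carries a different ring at the same oxygen, but it also differs elsewhere, so its number can only hint that such rings tolerate variation. Compound 4 is therefore expected to stay close to compound 1, with the step of a 1.3-fold higher number from compound 1 to compound 4 (0.11 log units; within the scatter) estimated to lie within or just beyond the scatter. The estimate for compound 4 in this assay is 5500 nM, within a range from 2000 nM to 15000 nM.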

Compound 4, half-maximal effective concentration: 307 nM
Compound 4: middle estimate off by 18-fold (1.25 log units), on the high side, and the stated range ends above it.
By their numbers in this assay, from the lowest: compound 4; then compound 3; then compound 2; then compound 1.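

In this assay, the group on this oxygen turns out to matter a great deal: phenyl in place of 4-methylpyridin-2-yl gives a 14-fold lower number from compound 1 to compound 4 (1.14 log units; beyond the scatter). For the compounds shown here, the only earlier single-place step added a trifluoromethyl, a 6.2-fold lower number from compound 1 to compound 3 (0.79 log units; beyond the scatter), whereas this one shows that a lower number can also be reached by adding nothing, with a plain carbon-only ring taking the place of the ring that carries a nitrogen and a methyl. Going by these compounds alone, nothing at hand explains why this exchange shifts the number so far.

On these data alone, the exchange removes the ring nitrogen and the methyl together, so their separate shares in the step remain unknown. A plain pyridin-2-yl or a 4-methylphenyl at the same oxygen would be needed to separate the two.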